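This account rests on a few compounds, and the source may have more. Where it says the series, first, only, none or still open, it means among the compounds named here.

Three compounds share one core and differ only in the group carried on a nitrogen on an aromatic ring. In a functional assay on NCI-H520 cells (Homo sapiens) for inhibition, read by MTT assay, with a stated time of 48 h, tested at 10 uM (a higher number here means more inhibition at the concentration tested (going by the name of the read-out), a lower number less inhibition), compound 1 `COc1ccc(F)cc1Nc1cc(NC(=O)Nc2c(Cl)cccc2Cl)ncn1` gives 38.1%, compound 2 `COc1cc(NC(=O)Nc2cc(Nc3ccc(C)c(C)c3)ncn2)cc(OC)c1` gives 29.5%, and compound 3 `Cc1cc(F)cc(Nc2cc(NC(=O)Nc3c(Cl)cccc3Cl)ncn2)c1` gives 60.5%. Compound 2 has the lowest of these three numbers: its gap to compound 1 lies within the scatter, its gap to compound 3 beyond it. Compound 4 `COc1cc(NC(=O)Nc2cc(Nc3ccc(F)c(Cl)c3)ncn2)cc(OC)c1` has not yet been measured; it differs from compound 2 by 3-chloro-4-fluorophenyl in place of 3,4-dimethylphenyl on a nitrogen on an aromatic ring. Among the compounds with values here, the one measured step that exchanges a group at that place, a number 22.4 percentage points higher from compound 1 to compound 3 (beyond the scatter), shows that such an exchange can shift the read-out modestly, though it sits on a different remainder of the molecule, and no measured step exchanges the groups that leave and enter here. A small rise is therefore expected, a number 8.5 percentage points higher from compound 2 to compound 4 (within the scatter). Compound 4 is expected to give 38%, between 20% and 58%.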

Compound 4, a percentage reported as inhibition, at one concentration (the size of the read-out at that concentration, not a potency): 25.5%
For compound 4 the middle estimate is 12.5 percentage points above the measured one; low and high end bracket the measured number.
By their numbers in this assay, from the lowest: compounds 4, 2 and 1 (each within the scatter of the next, the first and the last beyond it); then compound 3.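

In this assay, 3-chloro-4-fluorophenyl in place of 3,4-dimethylphenyl gives a number 4 percentage points lower from compound 2 to compound 4 (within the scatter). On the core of compound 2, then, this exchange on the nitrogen does not separate the two compounds, so a new group at this place need not move the number beyond the scatter. Nothing available explains this result. Still open, as far as these compounds go, is whether 3-chloro-4-fluorophenyl would behave alike on the core of compound 3, and whether a non-aromatic group on that nitrogen, such as a longer chain ending in an amine, would shift the number.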